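Swapping the Pyridinyl Attachment on Two Related Cores

This account rests on a few compounds, and the source may have more. Where it says the series, first, only, none or still open, it means among the compounds named here.

Compound 1 `COc1cccc(Nc2nccc(-c3ccncc3)n2)c1` and compound 2 `COc1cccc(Nc2nccc(-c3cccnc3)n2)c1` are built on the same core and differ in one place only. In a functional assay for inhibition, with Homo sapiens as the target (on this read-out lower numbers stand for stronger inhibition and higher numbers for weaker inhibition), compound 1 gives 400 nM, and compound 2 gives 300 nM. The change between them is pyridin-3-yl in place of pyridin-4-yl on an aromatic carbon, and it made a step of a 1.3-fold lower number from compound 1 to compound 2 (0.12 log units; within the scatter), so the two numbers cannot be told apart with confidence.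

Compound 3 `NS(=O)(=O)c1ccc(Nc2nccc(-c3ccncc3)n2)cc1` carries a sulfonamide-bearing ring where compound 1 carries a methoxy-bearing one; the difference between the two cores is not broken down here. In this assay compound 3 gives 5100 nM, the highest of the three numbers, and the gaps to compound 1 and to compound 2 are both beyond the scatter.

Compound 4 `NS(=O)(=O)c1ccc(Nc2nccc(-c3cccnc3)n2)cc1` has not yet been measured. It stands to compound 3 as compound 2 stands to compound 1: pyridin-3-yl in place of pyridin-4-yl on an aromatic carbon. The surroundings are described a little differently, "meta to a group of 9 heavy atoms" in the first pair and "meta to a large group" in the second, so this is the same kind of change rather than the same one. Because the earlier step of a 1.3-fold lower number from compound 1 to compound 2 (0.12 log units; within the scatter) stayed within the scatter, compound 4 is expected to sit close to compound 3, with an estimated step of a 1.3-fold lower number from compound 3 to compound 4 (0.11 log units; within the scatter). The expected value for compound 4 in this assay is 4000 nM, estimated to lie between 1500 nM and 11000 nM.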

Compound 4, half-maximal inhibitory concentration: 200 nM
Estimate against measurement, compound 4: 20-fold (1.30 log units) above; measured number below the stated range.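

On the sulfonamide-bearing core, putting pyridin-3-yl in place of pyridin-4-yl gives, in this assay, a large step of a 26-fold lower number from compound 3 to compound 4 (1.41 log units; beyond the scatter). The change therefore does not carry over at the same size from the methoxy-bearing core to the sulfonamide-bearing one, and a step read on one core in this series is a poor guide to the step on the other: the same change on two cores in this assay, a 1.3-fold lower number (0.12 log units; within the scatter) from compound 1 to compound 2 and a 26-fold lower number (1.41 log units; beyond the scatter) from compound 3 to compound 4, 19-fold (1.28 log units) apart, beyond the scatter of two such steps. This shows that the effect of the swap depends on the core it sits on, but it does not show which feature of the core is responsible or why, and two cores are too few to support a general rule.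

The compounds shown leave open whether a core carrying a carboxylic acid or an amine in place of the sulfonamide would behave like the pair compound 3 and compound 4 or like the pair compound 1 and compound 2. They also leave open how pyridin-2-yl or a plain phenyl ring would compare with pyridin-3-yl and pyridin-4-yl at the same place on either core.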